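The compounds below may be only part of what the source reports. "The series", "measured", "known", "first", "only" and "open" are said of these compounds alone.

Working notes on the series.

The parent compound 1 `Nc1ccc(C2=NNC(=O)CC2)cc1` in a functional assay for inhibition, with Homo sapiens as the target (a lower number here means that less compound is needed, a higher number that more compound is needed for the effect), gives 46.4 ug/mL. Acylation of the aromatic amine lowers the number sharply: compound 2 `O=C1CCC(c2ccc(NC(=O)CCl)cc2)=NN1` gives 0.39 ug/mL, and compound 3 `CCC(Cl)C(=O)Nc1ccc(C2=NNC(=O)CC2)cc1` gives 1.47 ug/mL. The steps are a 120-fold lower number from compound 1 to compound 2 (2.08 log units; beyond the scatter) and a 32-fold lower number from compound 1 to compound 3 (1.50 log units; beyond the scatter), while the ethyl that distinguishes the two acyl groups costs a 3.8-fold higher number from compound 2 to compound 3 (0.58 log units; beyond the scatter). Compound 3 thus stands second highest of the three numbers: nearest to compound 2 and far from compound 1, both gaps beyond the scatter.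

The next compound, compound 4 `CCN(CC)CC(=O)Nc1ccc(C2=NNC(=O)CC2)cc1`, differs from compound 3 as follows: a group of 6 heavy atoms (5 carbon, 1 nitrogen; no ring) in place of a group of 4 heavy atoms (3 carbon, 1 chlorine; no ring), on a carbonyl carbon. Among the compounds with values here, both large steps measured so far, from compound 1 to compound 2 and from compound 1 to compound 3, were produced by chains that carry chlorine; compound 4 carries no chlorine, and no measured compound carries a (diethylamino)methyl group, so there is no direct precedent for it. The expectation is therefore a higher number than compound 3, of uncertain size, with the step estimated as a 4.1-fold higher number from compound 3 to compound 4 (0.61 log units; beyond the scatter). For compound 4 in this assay the estimate is 6 ug/mL, with a range from 1.5 ug/mL to 30 ug/mL.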

Compound 4, half-maximal effective concentration: about 10 ug/mL
The estimate for compound 4 lay 1.7-fold (0.22 log units) below the measured number; measured number inside the range.
By their numbers in this assay, from the lowest: compound 2; then compound 3; then compound 4; then compound 1.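

Within the data shown here, at this position, on a carbonyl carbon whose other neighbours are the amide-type nitrogen, the first group without chlorine gives a clearly higher number in this assay than either chlorine-bearing chain. The (diethylamino)methyl group in place of the chain of compound 3 gives a 6.8-fold higher number from compound 3 to compound 4 (0.83 log units; beyond the scatter) and the swap of chloro for diethylamino on the saturated chain carbon gives a 26-fold higher number from compound 2 to compound 4 (1.41 log units; beyond the scatter), the larger of the two steps. Chlorine is nevertheless not needed for some lowering of the number, as compound 4 gives about 10 ug/mL while compound 1 gives 46.4 ug/mL, so acylation with this chain still leaves the printed value under that of the free amine, though the two chlorine-bearing compounds remain lower.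

The compounds shown leave open whether the low numbers follow the chlorine itself or the small chain that carries it, which a bromomethyl or methoxymethyl group on the same carbonyl carbon would separate. They also leave open whether the rise with diethylamino belongs to the amine as such or to its two ethyl groups, a question for a dimethylamino or unsubstituted aminomethyl chain. No measurement bears on why these steps have the sizes they have.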